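Brain protein binding: dropping a fluoro from compound 1

A few compounds are considered here, and "the series" means these few. Any claim that something is new, unique, unknown or untested is made for them only; others in the source may bear on it.

Measured so far:
compound 1 `O=C1O[C@]2(CC[C@H](CNc3cnn(-c4ccccc4F)c3)CC2)CN1c1cccnc1F`: 0.019
compound 2 `O=C1O[C@]2(CC[C@H](CNc3ccc(-c4cc(F)cc(F)c4)nn3)CC2)CN1c1cccnn1`: 0.016
compound 3 `O=C1O[C@]2(CC[C@H](CNc3ccc(-c4nccs4)cn3)CC2)CN1c1ccccn1`: "not determined" (no result reported)

In an ADME assay on brain (Rattus norvegicus) for protein binding (a lower number here means a smaller unbound share, a higher number a larger unbound share of the compound), compound 1 gives 0.019 and compound 2 gives 0.016; the gap between them lies within the scatter, so neither is set above the other. Compound 3 stands at "not determined" (no result reported) in this assay. Compound 4 `O=C1O[C@]2(CC[C@H](CNc3cnn(-c4ccccc4F)c3)CC2)CN1c1cccnc1` differs from compound 1 only by hydrogen in place of fluoro on an aromatic carbon. Within the data shown here, no pair of measured compounds shows this change, so its size must be guessed. The expectation is a small shift toward a larger unbound share, not clearly beyond the scatter, estimated as a 1.3-fold higher number from compound 1 to compound 4 (0.12 log units; within the scatter). Compound 4 is therefore expected at 0.025, within a range of 0.013 to 0.045.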

Compound 4, unbound fraction: 0.025
For compound 4 middle estimate and measured number coincide at the digits printed, and the stated range covers the measured number.
By their numbers in this assay, from the lowest: compounds 2, 1 and 4 (each within the scatter of the next).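

Hydrogen in place of fluoro gives the first single-place step in the series, and in this assay it reads a 1.3-fold higher number from compound 1 to compound 4 (0.12 log units; within the scatter) with only the 2-fluoropyridin-3-yl to pyridin-3-yl exchange separating the two compounds. At this aromatic carbon next to the ring nitrogen, the fluoro can thus be absent without the read-out separating the pair. Nothing measured here bears on the reason for this result.

Going by these compounds, whether a chloro, methoxy or amino group on this carbon would give a step beyond the scatter remains open. So does whether the same exchange reads alike with other groups elsewhere on the shared core.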